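Chloro for Nitro on Two Related Cores

The compounds below may be only part of what the source reports. "The series", "measured", "known", "first", "only" and "open" are said of these compounds alone.

Measured compounds:
compound 1, `Clc1ccc(Nc2cncc(N3CC4CC(C3)N4)c2)cc1`, 0.118 nM
compound 2, `O=[N+]([O-])c1ccc(Nc2cncc(N3CC4CC(C3)N4)c2)cc1`, 0.0225 nM
compound 3, `O=[N+]([O-])c1ccc(Nc2ccc(N3CC4CC(C3)N4)nn2)cc1`, 86.2 nM

Of the compounds shown here, three have been measured in an assay on cell membranes for displacement of a labelled ligand from Neuronal acetylcholine receptor; alpha4/beta2 (Rattus norvegicus); on this read-out lower numbers stand for stronger inhibition and higher numbers for weaker inhibition. Compound 2 gives 0.0225 nM, and compound 1 gives 0.118 nM. The two differ in one place: chloro in place of nitro on an aromatic carbon. That change made a 5.2-fold higher number from compound 2 to compound 1 (0.72 log units; beyond the scatter).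

Compound 3 stands on a different core from compound 2; the difference between the two cores is not broken down here. In this assay compound 3 gives 86.2 nM, the highest number of the three, far beyond the scatter from both compound 1 and compound 2.

Compound 4, `Clc1ccc(Nc2ccc(N3CC4CC(C3)N4)nn2)cc1`, has not been measured. It stands to compound 3 as compound 1 stands to compound 2: chloro in place of nitro on an aromatic carbon. The place is described in the same words for both pairs, so this is the same change, made for the second time among these compounds.

Among the measured compounds shown here, only one earlier instance of the change exists, and it sits on the other core, so it is not known whether the step carries over. Taking it as the best guide, compound 4 is expected to give a higher number than compound 3, with an estimated step of a 4.4-fold higher number from compound 3 to compound 4 (0.64 log units; beyond the scatter), because compound 1 showed a 5.2-fold higher number from compound 2 to compound 1 (0.72 log units; beyond the scatter). The expected value for compound 4 is 380 nM, estimated to lie between 110 nM and 1300 nM.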

Compound 4, inhibition constant: 90.4 nM
For compound 4 the middle estimate is 4.2-fold (0.62 log units) above the measured one, and the stated range ends above it.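

In this assay, the change from nitro to chloro on the core of compound 3 gave a 1.0-fold higher number from compound 3 to compound 4 (0.02 log units; within the scatter), so on this core the two groups cannot be told apart on this read-out. The same change therefore does not carry over in size from one core to the other, and the step seen on the core of compound 1 could not have been transferred as it stood: the same change on two cores in this assay, a 5.2-fold higher number (0.72 log units; beyond the scatter) from compound 2 to compound 1 and a 1.0-fold higher number (0.02 log units; within the scatter) from compound 3 to compound 4, 5.0-fold (0.70 log units) apart, beyond the scatter of two such steps. This shows that the effect of the change depends on the core in this small series, but with a single pair on each core it does not show which feature of the cores is responsible, nor how the change would behave on any further core.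

The compounds shown leave open how other groups in the same place on the six-membered aromatic ring of carbon only, such as a methoxy group, an amine or a plain hydrogen, would read on each of the two cores. They also leave open whether such groups would separate as widely on the core of compound 1 and stay as close together on the core of compound 3 as nitro and chloro do.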